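Dichlorobenzyl isomers: compound 3 to compound 4

The source may report more compounds than this note shows. Statements on the series, on what has been measured and on what is new or still open speak of the compounds shown alone.

In a functional assay on Jurkat cells (Homo sapiens) (on this read-out lower numbers stand for stronger inhibition and higher numbers for weaker inhibition), compound 3 (`C[C@H](NC(=O)C(=O)NCc1ccc(Cl)cc1Cl)C(=O)N[C@@H](CC(=O)O)C(=O)COc1c(F)c(F)cc(F)c1F`) gives 165 nM and compound 1 (`C[C@H](NC(=O)C(=O)NCc1ccccc1F)C(=O)N[C@@H](CC(=O)O)C(=O)COc1c(F)c(F)cc(F)c1F`) gives 207 nM, so the two sit level, with a 1.3-fold lower number from compound 1 to compound 3 (0.10 log units; within the scatter) between them. Compound 2 (`Cc1ccc(C)c(CNC(=O)C(=O)N[C@@H](C)C(=O)N[C@@H](CC(=O)O)C(=O)COc2c(F)c(F)cc(F)c2F)c1`) gives 11 nM as the lowest number of the three, and a 15-fold higher number from compound 2 to compound 3 (1.18 log units; beyond the scatter) marks how far compound 3 lies from it.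

The next change is 2,5-dichlorophenyl in place of 2,4-dichlorophenyl on a saturated chain carbon bound to an amide-type nitrogen and gives compound 4 (`C[C@H](NC(=O)C(=O)NCc1cc(Cl)ccc1Cl)C(=O)N[C@@H](CC(=O)O)C(=O)COc1c(F)c(F)cc(F)c1F`), with 2,5-dichlorophenyl in place of 2,4-dichlorophenyl on a saturated chain carbon bound to an amide-type nitrogen.

For the measured compounds named here, the nearest precedent is compound 2, which carries 2,5-dimethylphenyl and shows a 19-fold lower number from compound 1 to compound 2 (1.27 log units; beyond the scatter) as its step. Going by the values given here, no measured pair compares chlorine with methyl in the same arrangement, so only part of that size is carried over. The expected step is a 4.7-fold lower number from compound 3 to compound 4 (0.67 log units; beyond the scatter), towards a lower number but short of the full gap. The estimated value for compound 4 is 35 nM with an expected range from 10 nM to 130 nM in this series.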

Compound 4, half-maximal inhibitory concentration: 4.3 nM
Estimate against measurement, compound 4: 8.1-fold (0.91 log units) above; the whole stated range lies above it.
By their numbers in this assay, from the lowest: compound 4; then compound 2; then compounds 3 and 1 (each within the scatter of the next).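

Moving one chlorine, with the same atoms and the same counts on both sides, gives a 38-fold lower number from compound 3 to compound 4 (1.58 log units; beyond the scatter) in this assay, so at this position the read-out separates the 2,5-dichlorophenyl and 2,4-dichlorophenyl isomers, and the presence of two chlorines does not fix the number on its own. Putting 2,5-dichlorophenyl in place of 2,5-dimethylphenyl gives a much smaller change, a 2.6-fold lower number from compound 2 to compound 4 (0.41 log units; beyond the scatter), against a 48-fold lower number from compound 1 to compound 4 (1.68 log units; beyond the scatter) from the 2-fluorophenyl group, and among these four the 2,5-dichlorophenyl and 2,5-dimethylphenyl groups give the lowest numbers. Nothing available explains the isomer difference.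

Open, going by these compounds, is whether methoxy or nitrile groups in place of the chlorines of 2,5-dichlorophenyl keep the number this low. Also open, on these data alone, is whether the isomer difference persists with an ethyl group in place of the methyl on the chain.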